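Difluoromethyl for Methyl on an Aromatic Ring

The source may hold more compounds than are shown below. What is called first, only, known or untested is meant among the compounds shown, and "the series" means these compounds.

Compound 1, `C[C@H](NS(=O)(=O)c1cc(C(F)(F)F)nn1C)c1nc(-c2cccc(F)c2)no1`: > 30000 nM, a limit only
Compound 2, `Cc1cc(-c2noc([C@H](C)NC(=O)c3cc(C(F)(F)F)nn3C)n2)ccn1`: 165 nM

Both compounds were tested in an assay on T-REx-293 cells for inhibition of potassium channel subfamily T member 1 (Homo sapiens), read by patch clamp; a higher number here means a weaker inhibitor, a lower number a stronger inhibitor. Compound 1 reaches only a limit there, > 30000 nM, so no number is known for it. Compound 2 gives 165 nM. Among the values shown, one sits at the limit of > 30000 nM in this assay, at which 1 of the 2 values shown sits, which leaves compound 2 as the only compound with a real number; there is no measured step against which to place it, and no comparison of its potency with that of compound 1 can be made beyond saying that compound 2 has a number and compound 1 has not.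

Compound 3, `C[C@H](NC(=O)c1cc(C(F)(F)F)nn1C)c1nc(-c2ccnc(C(F)F)c2)no1`, has not been measured. It differs from compound 2 in one place: difluoromethyl in place of methyl on an aromatic carbon. Among the measured compounds shown here, no pair of measured compounds in this set shows that change, so any expectation rests on compound 2 alone. The step from compound 2 to compound 3 is expected to be small, a 1.1-fold higher number from compound 2 to compound 3 (0.04 log units; within the scatter), not clearly beyond the usual scatter in either direction. Compound 3 is therefore estimated to give about 180 nM, most likely between 60 nM and 550 nM.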

Compound 3, half-maximal inhibitory concentration in the potassium channel subfamily T member 1 assay: 61 nM
Estimate against measurement, compound 3: 3.0-fold (0.47 log units) above, and the stated range covers the measured number.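

In the potassium channel subfamily T member 1 assay, putting difluoromethyl in place of methyl on the aromatic carbon next to the ring nitrogen gives a 2.7-fold lower number from compound 2 to compound 3 (0.43 log units; beyond the scatter), so this position accepts a group of 3 heavy atoms where a group of 1 heavy atom stood before. In a physicochemical assay for lipophilicity (on this read-out lower numbers stand for lower lipophilicity and higher numbers for higher lipophilicity), compound 2 gives 3.3 and compound 3 gives 3.4. In the physicochemical assay the same change gives a number 0.10 log units higher from compound 2 to compound 3 (within the scatter), so compound 2 and compound 3 cannot be told apart on that read-out, and the step in channel inhibition appears without a matching step there. Nothing shown here bears on why the number falls with this change at this position.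

On these data alone, whether a different group on this carbon, such as an amine, a methoxy group or a single chlorine atom, would lower the number further remains open. The step also rests on one pair of compounds, so it cannot be said whether difluoromethyl for methyl would do the same on another carbon of this ring or on a different core.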